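The source may report more compounds than this note shows. Statements on the series, on what has been measured and on what is new or still open speak of the compounds shown alone.

Of the compounds shown here, two built on the same core have been tested in an assay on isolated protein for inhibition of DNA topoisomerase 1 (Homo sapiens), with a stated time of 30 min, tested at 100 uM; a higher number here means more inhibition at the concentration tested (going by the name of the read-out), a lower number less inhibition. Compound 1 `Oc1ccc(-c2cc(-c3ccccc3O)cc(-c3cccc(O)c3)n2)cc1` shows no measurable effect, giving 0% in this assay. Compound 2 `Oc1ccccc1-c1cc(-c2ccccc2O)nc(-c2ccccc2O)c1` gives 0% in this assay, so compound 2 stands level with compound 1 at the digits reported, with no change between the two beyond the scatter. Compound 3 `Oc1ccc(-c2cc(-c3ccccc3O)cc(-c3ccccc3O)n2)cc1` has not yet been measured. It differs from compound 2 in one place: 4-hydroxyphenyl in place of 2-hydroxyphenyl on an aromatic carbon. The two have the same atoms, joined differently. Within the data shown here, because compound 2 gives 0% and compound 1 gives 0%, neither measured compound offers any sign of activity to build on, and no step between measured compounds shows how such a rearrangement moves the read-out. The change is therefore expected to amount to no change at the digits printed from compound 2 to compound 3 (within the scatter), nothing beyond the scatter. Compound 3 is estimated to give 0% in this assay, with a range from -8% to 10%.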

Compound 3, a percentage reported as inhibition, at one concentration (the size of the read-out at that concentration, not a potency): 0.3%
Compound 3: middle estimate off by 0.3 percentage points, on the low side; the range from low to high includes it.
By their numbers in this assay, from the lowest: compounds 1, 2 and 3 (each within the scatter of the next).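

Placing 4-hydroxyphenyl in place of 2-hydroxyphenyl on the aromatic carbon next to the ring nitrogen, meta to two 2-hydroxyphenyl groups, gives in this assay a number 0.3 percentage points higher from compound 2 to compound 3 (within the scatter), so this exchange at this position shows no effect that can be told from the scatter. The second exchange, 2-hydroxyphenyl in place of 3-hydroxyphenyl on an aromatic carbon, gives a number 0.3 percentage points higher from compound 1 to compound 3 (within the scatter), so it too leaves the result within the scatter, and the three arrangements of the hydroxyphenyl groups shown here cannot be told apart in this assay. No accompanying measurement offers an explanation for this flat result.

With all three compounds this close to zero, the set gives no starting point for reading how this position influences inhibition, and it cannot show whether any group on the shared core would produce a measurable effect. It leaves open whether an amine or a carboxylic acid in place of the hydroxy group on one of these phenyl rings would bring the number clear of the scatter.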